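The compounds below may be only part of what the source reports. "The series", "measured", "known", "first", "only" and "open" are said of these compounds alone.

Of the compounds shown here, three built on one shared core have been measured in a functional assay on HT-1080 cells (Homo sapiens) for inhibition, read by MTT assay, with a stated time of 48 h; on this read-out lower numbers stand for stronger inhibition and higher numbers for weaker inhibition. Compound 1 `COc1cc(-c2nc3cc(/C=C4\SC(=O)N(CC(=O)N5CCOCC5)C4=O)ccc3[nH]2)cc(OC)c1OC` gives 1680 nM, compound 2 `COc1cc(-c2nc3cc(/C=C4\SC(=O)N(CC(=O)N5CCCCC5)C4=O)ccc3[nH]2)cc(OC)c1OC` gives 3650 nM, and compound 3 `COc1cc(-c2nc3cc(/C=C4\SC(=O)N(Cc5ccccc5)C4=O)ccc3[nH]2)cc(OC)c1OC` gives 660 nM. Compound 3 thus holds the lowest of the three numbers: a 2.5-fold lower number from compound 1 to compound 3 (0.41 log units; beyond the scatter) and a 5.5-fold lower number from compound 2 to compound 3 (0.74 log units; beyond the scatter), while a 2.2-fold higher number from compound 1 to compound 2 (0.34 log units; beyond the scatter). Compound 4 `COc1cc(CN2C(=O)S/C(=C\c3ccc4[nH]c(-c5cc(OC)c(OC)c(OC)c5)nc4c3)C2=O)cc(OC)c1OC` differs from compound 3 in one place: 3,4,5-trimethoxyphenyl in place of phenyl on a saturated chain carbon bound to an amide-type nitrogen in a ring. The measured steps all concern the group on that same chain carbon and show that changing it moves this assay by modest amounts, but none of them adds methoxy groups to a phenyl, so they give only weak guidance here. The account therefore expects the move to compound 4 to be small, a 1.1-fold higher number from compound 3 to compound 4 (0.03 log units; within the scatter), not beyond the scatter. Compound 4 is estimated at 700 nM, with a range from 280 nM to 1800 nM.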

Compound 4, half-maximal inhibitory concentration: 980 nM
The estimate for compound 4 lay 1.4-fold (0.15 log units) below the measured number; the measured number falls inside the stated range.
By their numbers in this assay, from the lowest: compounds 3, 4 and 1 (each within the scatter of the next, the first and the last beyond it); then compound 2.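

In this assay, among the compounds shown here, the first change to the phenyl itself, adding methoxy groups to give 3,4,5-trimethoxyphenyl, stays within the scatter (a 1.5-fold higher number from compound 3 to compound 4 (0.17 log units; within the scatter)). This group keeps a gap beyond the scatter against (piperidin-1-yl)carbonyl (a 3.7-fold lower number from compound 2 to compound 4 (0.57 log units; beyond the scatter)) but not against (morpholin-4-yl)carbonyl (a 1.7-fold lower number from compound 1 to compound 4 (0.23 log units; within the scatter)). No evidence is available to explain these results. Still open, as far as these compounds go, is whether an amine or a carboxylic acid on the phenyl would move the number beyond the scatter, and whether a longer chain on the amide-type nitrogen in the ring would do so.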